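The source may report more compounds than this note shows. Statements on the series, on what has been measured and on what is new or still open speak of the compounds shown alone.

Compound 1 `CC1(C)CO[C@H]1CN([C@H](CCC(F)(F)F)C(N)=O)S(=O)(=O)c1ccc(Cl)cc1` heads the small set: in an ADME assay on MDCKII-LE cells (Canis lupus familiaris) for permeability, read by transwell migration, in the apical to basolateral direction (on this read-out higher numbers stand for higher permeability and lower numbers for lower permeability), compound 1 gives 26.4 10^-6 cm/s. For the measured compounds named here, compound 2 `NC(=O)[C@@H](CCC(F)(F)F)N(C[C@H]1CCCOC1)S(=O)(=O)c1ccc(Cl)cc1` gives 18.2 10^-6 cm/s in this assay, and the only measured step, a 1.5-fold lower number from compound 1 to compound 2 (0.16 log units; within the scatter), exchanges the ring on the saturated chain carbon bound to the sulfonamide nitrogen and leaves the two compounds within the scatter of each other.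

The next compound, compound 3 `NC(=O)[C@@H](CCC(F)(F)F)N(C[C@H]1CCO1)S(=O)(=O)c1ccc(Cl)cc1`, differs from compound 1 by oxetan-2-yl in place of 3,3-dimethyloxetan-2-yl on a saturated chain carbon bound to a sulfonamide nitrogen. Going by the values given here, only the step from compound 1 to compound 2 bears on this change, since it alters the same position, and it was within the scatter. An exchange of one ring for another at this site therefore gives no ground to expect a step beyond the scatter in this assay; at most a modest drop is anticipated. Compound 3 is estimated at 17 10^-6 cm/s, with a range of 9 10^-6 cm/s to 30 10^-6 cm/s, which means an expected step of a 1.6-fold lower number from compound 1 to compound 3 (0.19 log units; within the scatter).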

Compound 3, apparent permeability: 28.7 10^-6 cm/s
The estimate for compound 3 lay 1.7-fold (0.23 log units) below the measured number, within the range that was stated.
By their numbers in this assay, from the lowest: compounds 2, 1 and 3 (each within the scatter of the next).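

At the saturated chain carbon bound to a sulfonamide nitrogen, oxetan-2-yl with 4 heavy atoms in place of 3,3-dimethyloxetan-2-yl with 6 gives in this assay a 1.1-fold higher number from compound 1 to compound 3 (0.04 log units; within the scatter) and so adds a second ring exchange at this place that stays within the scatter. Against the oxan-3-yl group, the same oxetan-2-yl group gives a 1.6-fold higher number from compound 2 to compound 3 (0.20 log units; within the scatter) and this closes the set: all three compounds now stand within the scatter of one another, and the read-out does not separate these three ring groups. No measurement at hand bears on this result.

From the compounds shown here alone, whether an amine, a carboxylic acid or an open alkyl chain at this place would give a step beyond the scatter stays open. So does whether the same holds once the rest of the shared core differs.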